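Acetamido Added to the Core of Compound 1

The source may report more compounds than this note shows. Statements on the series, on what has been measured and on what is new or still open speak of the compounds shown alone.

Three compounds have been run in a functional assay on A549 cells (Homo sapiens) for inhibition, read by MTT assay, with a stated time of 48 h; on this read-out higher numbers stand for weaker inhibition and lower numbers for stronger inhibition. Compound 1 `COc1cc2ccc(=O)oc2cc1OCCCOc1no[n+]([O-])c1S(=O)(=O)c1ccccc1` gives 5450 nM, the lowest of the three numbers. Compound 2 `COc1cc2ccc(=O)oc2cc1OCCCCOc1no[n+]([O-])c1S(=O)(=O)c1ccccc1` gives 6140 nM, and compound 3 `COc1cc2ccc(=O)oc2cc1OCCCCCOc1c[n+]([O-])on1` gives 10600 nM; both of these sit within the scatter of compound 1, so no order among the three can be claimed. Compound 4 `COc1cc2cc(NC(C)=O)c(=O)oc2cc1OCCCOc1no[n+]([O-])c1S(=O)(=O)c1ccccc1` differs from compound 1 by acetamido in place of hydrogen on an aromatic carbon. Within the data shown here, no measured pair shows what such a change does on this core, so the direction of the step is open. The step from compound 1 to compound 4 is expected to be a 1.0-fold higher number from compound 1 to compound 4 (0.00 log units; within the scatter), hardly beyond the scatter. Compound 4 is therefore estimated at 5500 nM, with a range from 2000 nM to 15000 nM.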

Compound 4, half-maximal inhibitory concentration: 9810 nM
Compound 4: the middle estimate sits 1.8-fold (0.25 log units) below what was measured, and the stated range covers the measured number.
By their numbers in this assay, from the lowest: compounds 1, 2, 4 and 3 (each within the scatter of the next).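

In this assay, acetamido in place of hydrogen on an aromatic carbon, two atoms from the ring oxygen, comes with a 1.8-fold higher number from compound 1 to compound 4 (0.26 log units; within the scatter). This first pair on the shared core shows that this position can carry the group with no step beyond the scatter. Nothing measured on the compounds gives a reason for this result.

From the compounds shown here alone, what an amine or a carboxylic acid would give at this position remains open. So does whether acetamido gives a similar step on the longer chain of compound 2.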